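Compound 3 in the Huh-7 cytotoxicity assay

The source may hold more compounds than are shown below. What is called first, only, known or untested is meant among the compounds shown, and "the series" means these compounds.

Measured in an ADME assay on Huh-7 cells (Homo sapiens) for cytotoxicity, with a stated time of 72 h; a higher number here means that more compound is tolerated, a lower number that less compound is tolerated:
- Compound 1 (`CC(C)(C)Cn1nc(-c2cccs2)c(O)c(C2=NS(=O)(=O)c3cc(NS(C)(=O)=O)ccc3N2)c1=O`) reads > 1000 nM as a limit
- Compound 2 (`CS(=O)(=O)Nc1ccc2c(c1)S(=O)(=O)N=C(c1c(O)c(-c3cccs3)nn(CC3(C(F)(F)F)CCC3)c1=O)N2`) reads > 1000 nM as a limit

Compound 2 has no exact number here. In this assay compound 2 reads > 1000 nM and this is a limit. Compound 1 shares that limit (the limit of > 1000 nM in this assay, at which 2 of the 2 values shown sit).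

The next compound is compound 3 (`CS(=O)(=O)Nc1ccc2c(c1)S(=O)(=O)N=C(c1c(O)c(-c3cccs3)nn(Cc3ccccn3)c1=O)N2`), which carries pyridin-2-yl in place of 1-(trifluoromethyl)cyclobutyl on a saturated chain carbon bound to an aromatic nitrogen. Within the data shown here, the one measured step changes the group at that same place (a step that the two limits leave unreadable from compound 1 to compound 2), but its size cannot be read, so it gives no size or direction to carry over. Among the measured compounds shown here, it shows only that compound 1 and compound 2, with different groups there, both sit at the limit (the limit of > 1000 nM in this assay, at which 2 of the 2 values shown sit).

Compound 3 is therefore expected to stay near that limit in this assay and may well be reported as a limit too. No step beyond the usual scatter is expected (a step that the limit leaves unreadable from compound 2 to compound 3). For compound 3 the estimated value is 2000 nM with an expected range (1000 nM to 10000 nM).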

Compound 3, half-maximal cytotoxic concentration: > 1000 nM
Compound 3: a limit, no number; the forecaster's own chance of this, stated with the estimate: 85%; the middle value is on the limit's open side.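

In this assay compound 3 reads > 1000 nM and this is a limit, not a number. Among these compounds, the steps linking compound 3 to compound 1 and compound 2 therefore cannot be read, so no new step emerges. Still open is whether changing the group on the saturated chain carbon bound to an aromatic nitrogen shifts the true values at all, as all three compounds share one reading: the limit of > 1000 nM in this assay, at which 3 of the 3 values shown sit.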